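A few compounds are considered here, and "the series" means these few. Any claim that something is new, unique, unknown or untested is made for them only; others in the source may bear on it.

Compound 2 `COc1cc(N(Cc2ccccc2)C(=O)CSc2nc3ccccc3s2)cc(OC)c1OC` and compound 1 `COc1ccc(CN(C(=O)CSc2nc3ccccc3s2)c2cc(OC)c(OC)c(OC)c2)cc1C` share the same core, a thioether-linked amide carrying a trimethoxyphenyl group, and differ only in the aromatic ring on the saturated chain carbon bound to the amide-type nitrogen. In a functional assay on PC-3 cells (Homo sapiens) for antiproliferative activity, read by MTT assay, with a stated time of 48 h (on this read-out higher numbers stand for weaker inhibition and lower numbers for stronger inhibition), compound 1 gives 34300 nM and compound 2 gives 54100 nM. The step of a 1.6-fold higher number from compound 1 to compound 2 (0.20 log units; within the scatter) means the two numbers cannot be told apart, so compound 2 stands level with its only companion.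

Compound 3 `COc1cc(N(Cc2ccc(F)cc2)C(=O)CSc2nc3ccccc3s2)cc(OC)c1OC` continues from compound 2 with a single change, (fluoro in place of hydrogen on an aromatic carbon). For the measured compounds named here, this touches the same ring that was altered in the one measured step, and that step stayed within the scatter even though it replaced a whole substituted ring by a bare phenyl. A single fluorine added to that ring is a smaller change still. Going by the values given here, no measured step points to a shift in either direction, so in this assay the expected step is a 1.1-fold lower number from compound 2 to compound 3 (0.03 log units; within the scatter), with no movement beyond the scatter. Compound 3 is therefore estimated at 50000 nM, within a range from 20000 nM to 125000 nM.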

Compound 3, half-maximal inhibitory concentration: 50800 nM
Estimate against measurement, compound 3: 1.0-fold (0.01 log units) below, and the stated range covers the measured number.
By their numbers in this assay, from the lowest: compounds 1, 3 and 2 (each within the scatter of the next).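

In this assay the change of hydrogen to fluoro, on an aromatic carbon para to a large group, gives a 1.1-fold lower number from compound 2 to compound 3 (0.03 log units; within the scatter) and so leaves the number where it was. For the compounds shown here, this is the first look at a one-atom change on this ring, whereas the earlier step swapped one whole substituted ring for another. The second comparison gives a 1.5-fold higher number from compound 1 to compound 3 (0.17 log units; within the scatter) and shows that 4-fluorophenyl, like phenyl, cannot be told apart from 4-methoxy-3-methylphenyl, so the three rings on this chain carbon stand level in this cell test.

Still open, from the compounds shown here alone, is whether any group at this place can move the number beyond the scatter, for example an amine or a carboxylic acid on the ring in place of the fluoro. Going by these compounds, it is equally open whether a longer chain between the amide-type nitrogen and the ring would change the picture, or whether changes elsewhere on the shared core matter more than changes to this ring. No supporting measurement is available that would explain why these three rings stand level.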